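Branching the Urea Substituent: Propyl to Isopropyl

The source may report more compounds than this note shows. Statements on the series, on what has been measured and on what is new or still open speak of the compounds shown alone.

Measured so far:
Compound 1, `CC(C)(N)C(=O)N[C@@H]1CCc2ccccc2N(Cc2ccc(-c3ccccc3CNC(N)=O)cc2)C1=O`: 21 nM
Compound 2, `CCCNC(=O)NCc1ccccc1-c1ccc(CN2C(=O)[C@H](NC(=O)C(C)(C)N)CCc3ccccc32)cc1`: 144 nM

In a functional assay (Pituitary gland cell) with Rattus norvegicus as the target (on this read-out lower numbers stand for an effect already at smaller amounts and higher numbers for an effect only at larger amounts of compound), compound 2 stands at the higher of the two numbers; its nearest neighbour is compound 1, and the step of a 6.9-fold higher number from compound 1 to compound 2 (0.84 log units; beyond the scatter) is the only one measured. Compound 3, `CC(C)NC(=O)NCc1ccccc1-c1ccc(CN2C(=O)[C@H](NC(=O)C(C)(C)N)CCc3ccccc32)cc1`, differs from compound 2 by isopropyl in place of propyl on an amide-type nitrogen. Within the data shown here, no measured step compares two chains of equal size, so the move from a straight chain to a branched one is expected to stay within the scatter. Compound 3 is therefore estimated at 150 nM, within a range of 60 nM to 400 nM. For compound 3 the expected step is a 1.0-fold higher number from compound 2 to compound 3 (0.02 log units; within the scatter).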

Compound 3, concentration for half-maximal effect: 270 nM
Compound 3: middle estimate off by 1.8-fold (0.26 log units), on the low side; measured number inside the range.
By their numbers in this assay, from the lowest: compound 1; then compounds 2 and 3 (each within the scatter of the next).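

On the amide-type nitrogen, branching the chain gives a 1.9-fold higher number from compound 2 to compound 3 (0.27 log units; within the scatter) in this assay and this stays within the scatter, so propyl and isopropyl cannot be told apart here. Against hydrogen at the same place, isopropyl gives a 13-fold higher number from compound 1 to compound 3 (1.11 log units; beyond the scatter) and this lies beyond the scatter, so the loss seen with propyl also appears with a branched chain of the same size. No measurement at hand explains these numbers.

Open, as far as these compounds go, is whether a smaller group such as methyl or ethyl falls nearer compound 1. A longer chain such as butyl, or a ring such as cyclopropyl, is also untested among these compounds.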